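Methoxy to hydroxy: compound 3 to compound 4

The compounds below may be only part of what the source reports. "The series", "measured", "known", "first", "only" and "open" are said of these compounds alone.

Measured so far, in a functional assay on KM12 cells (Homo sapiens) for inhibition, read by sulforhodamine B assay, with a stated time of 48 h; on this read-out lower numbers stand for stronger inhibition of growth and higher numbers for weaker inhibition of growth:
- compound 1 `O=C(Nc1cccc(-n2cc(-c3ccncc3)c(-c3ccc(Cl)c(O)c3)n2)c1)Nc1cccc(C(F)(F)F)c1`: 1330 nM
- compound 2 `COc1cc(-c2nn(-c3cccc(NC(=O)c4cccc(C(F)(F)F)c4)c3)cc2-c2ccncc2)ccc1Cl`: 1660 nM
- compound 3 `COc1cc(-c2nn(-c3cccc(NC(=O)Nc4ccc(Cl)c(Cl)c4)c3)cc2-c2ccncc2)ccc1Cl`: 811 nM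

Compound 3 has the lowest number of the three; the gap to compound 1 is within the scatter, the gap to compound 2 is beyond it, so compound 3 is not called the most potent. The single one-place step shown is a 2.0-fold lower number from compound 2 to compound 3 (0.31 log units; beyond the scatter).

Compound 4 `O=C(Nc1cccc(-n2cc(-c3ccncc3)c(-c3ccc(Cl)c(O)c3)n2)c1)Nc1ccc(Cl)c(Cl)c1` differs from compound 3 by hydrogen in place of methyl on an oxygen on an aromatic ring. Going by the values given here, no measured step shows a methoxy-to-hydroxy change on its own: compound 1 carries the hydroxy and compound 2 the methoxy, but they differ in a second place as well, so their values alone cannot be read as this change. Among the compounds with values here, with no direct precedent, the expectation for compound 4 in this assay is a step of about a 1.1-fold lower number from compound 3 to compound 4 (0.03 log units; within the scatter), not beyond the scatter. Compound 4 is therefore estimated at 750 nM, range 300 nM to 1900 nM.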

Compound 4, concentration for 50% growth inhibition: 1010 nM
The estimate for compound 4 lay 1.3-fold (0.13 log units) below the measured number; low and high end bracket the measured number.
By their numbers in this assay, from the lowest: compounds 3, 4, 1 and 2 (each within the scatter of the next, the first and the last beyond it).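

In this assay, the change from methoxy to hydroxy on the aromatic ring can now be read on its own: a 1.2-fold higher number from compound 3 to compound 4 (0.10 log units; within the scatter) does not separate the two groups at this position. With the hydroxy held constant, 3,4-dichlorophenyl in place of 3-(trifluoromethyl)phenyl on the amide-type nitrogen gives a 1.3-fold lower number from compound 1 to compound 4 (0.12 log units; within the scatter) and does not separate those two groups either. No supporting evidence bears on this result.

On these data alone, a longer chain on that oxygen, or an amine in place of the hydroxy, remains open. So does whether the methoxy-to-hydroxy step stays this small alongside 3-(trifluoromethyl)phenyl.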